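The compounds below may be only part of what the source reports. "The series", "measured", "known", "first", "only" and "open" are said of these compounds alone.

Working notes on the series. In an ADME assay on the whole organism for metabolic stability, with Canis familiaris (Canis lupus familiaris) as the target, read by LC-MS, at a dose of 3 mg/kg by the oral route (on this read-out higher numbers stand for a longer-lived compound and lower numbers for a shorter-lived compound), compound 1 (`Cc1cc(C(=O)N[C@H]2CCCCC/C=C\[C@@H]3C[C@@]3(C(=O)NS(=O)(=O)C3CC3)NC(=O)[C@@H]3C[C@@H](Oc4nc5ccccc5nc4C(F)(F)F)CN3C2=O)no1`) gives 1.5 h and compound 2 (`Cc1cc(C(=O)N[C@H]2CCCCC/C=C\[C@@H]3C[C@@]3(C(=O)NS(=O)(=O)C3CC3)NC(=O)[C@@H]3C[C@@H](Oc4nc5cc(F)ccc5nc4C(F)(F)F)CN3C2=O)no1`) gives 2.2 h. Among the measured compounds shown here, the only measured step, a 1.5-fold higher number from compound 1 to compound 2 (0.17 log units; within the scatter), is fluoro in place of hydrogen on an aromatic carbon. It lies within the scatter, so compound 2 stands level with compound 1 on the two numbers available.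

Compound 3 (`Cc1cc(C(=O)N[C@H]2CCCCC/C=C\[C@@H]3C[C@@]3(C(=O)NS(=O)(=O)C3(C)CC3)NC(=O)[C@@H]3C[C@@H](Oc4nc5cc(F)ccc5nc4C(F)(F)F)CN3C2=O)no1`) is the next to be read. It differs from compound 2 by methyl in place of hydrogen on a saturated ring carbon, turning cyclopropylsulfonyl into (1-methylcyclopropyl)sulfonyl. For the measured compounds named here, no measured step covers a change at this group. The step of a 1.5-fold higher number from compound 1 to compound 2 (0.17 log units; within the scatter) bears on it only indirectly, as the sole indication of how far this assay has moved within the series. The data support no direction, and no step beyond the scatter is expected. The expected size is no change at the digits printed from compound 2 to compound 3 (within the scatter). For compound 3 the estimated half-life is 2.2 h, with an expected range of 1.1 h to 4.4 h.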

Compound 3, half-life: 2.9 h
Beside the measured number, compound 3's estimate is 1.3-fold (0.12 log units) below it, and the stated range covers the measured number.
By their numbers in this assay, from the lowest: compounds 1, 2 and 3 (each within the scatter of the next).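

Among the compounds shown here, this is the first reading at the sulfonyl end of the series: in this assay, methyl in place of hydrogen on a saturated ring carbon of the three-membered ring gives a 1.3-fold higher number from compound 2 to compound 3 (0.12 log units; within the scatter). Turning cyclopropylsulfonyl into (1-methylcyclopropyl)sulfonyl therefore leaves compound 3 level with compound 2 on this read-out, so this position accepts a methyl group without a step beyond the scatter, at least with the fluoro group of compound 2 in place. Nothing available explains this outcome or shows how the half-life is set at this position.

Still open, as far as these compounds go, is whether a larger or different group on this ring carbon, such as an ethyl group, a hydroxymethyl group or an amine, would move the half-life beyond the scatter. Also open, from the compounds shown here alone, is whether the same methyl group reads the same way on the core of compound 1, which lacks the fluoro group, since this single pair shows the change on one background only.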